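Cytotoxicity Limits for Three Compounds and One Untested Analogue

The source may report more compounds than this note shows. Statements on the series, on what has been measured and on what is new or still open speak of the compounds shown alone.

Compound 1, `COC(=O)c1cc(-c2cccc(NC(=O)c3ccc(OCc4ccc(Cl)cc4)cc3)c2)on1`: in an ADME assay on Vero cells (Chlorocebus sabaeus) for cytotoxicity, read by MTT assay, with a stated time of 72 h (on this read-out lower numbers stand for higher toxicity in this test and higher numbers for lower toxicity in this test), compound 1 gives > 80 ug/mL, which is a limit of the assay and not a number.
Compound 2, `CCCOc1ccc(C(=O)/C=C/c2ccc(C(=O)Nc3cccc(-c4cc(C(=O)OC)no4)c3)cc2)cc1`: in this assay compound 2 gives > 40 ug/mL, again only a limit.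
Compound 3, `COC(=O)c1cc(-c2cccc(NC(=O)c3ccc(/C=C/C(=O)c4ccc(OC)cc4)cc3)c2)on1`: in this assay compound 3 gives > 10 ug/mL, also a limit.

Compound 3 thus stands at a limit in this assay, as do the two other compounds shown; none of the three gives a number. The step that the two limits leave unreadable from compound 1 to compound 3 cannot be read, and the same holds for a step that the two limits leave unreadable from compound 2 to compound 3, because each end sits at one of the limits (the limit of > 10 ug/mL in this assay, at which 1 of the 3 values shown sits), the limit of > 40 ug/mL in this assay, at which 1 of the 3 values shown sits, and (the limit of > 80 ug/mL in this assay, at which 1 of the 3 values shown sits).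

Compound 4, `COC(=O)c1cc(-c2cccc(NC(=O)c3ccc(/C=C/C(=O)c4cccc(Br)c4)cc3)c2)on1`, differs from compound 3 by 3-bromophenyl in place of 4-methoxyphenyl on a carbonyl carbon. For the measured compounds named here, no measured step bears on this change, and the two measured steps give no size to lean on. Compound 4 is therefore expected to remain at a limit in this assay, with the step that the limit leaves unreadable from compound 3 to compound 4 expected to show nothing beyond the scatter. The estimate for compound 4 is 40 ug/mL, with a range from 10 ug/mL to 160 ug/mL.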

Compound 4, half-maximal cytotoxic concentration: > 100 ug/mL
Compound 4 was reported as a limit; the forecaster's own chance of this, stated with the estimate: 70%; at least 2.5-fold (0.39 log units) between middle value and limit.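

Compound 4, like compound 1, compound 2 and compound 3, gives only a limit in this assay, and none of the steps joining compound 4 to those three can be read. The compounds shown leave open whether 3-bromophenyl in place of 4-methoxyphenyl changes cytotoxicity at all.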